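The source may report more compounds than this note shows. Statements on the series, on what has been measured and on what is new or still open speak of the compounds shown alone.

Measured in an assay on RBL cells for inhibition of Polyunsaturated fatty acid 5-lipoxygenase (Rattus norvegicus); on this read-out lower numbers stand for stronger inhibition and higher numbers for weaker inhibition:
- compound 1 `COc1cc(-c2cc3cc(C(C)N(O)C(C)=O)ccc3o2)cc(OC)c1OC`, this assay 310 nM
- compound 2 `CC(c1ccc2oc(-c3ccccc3)cc2c1)N(O)C(=O)c1cccs1`, this assay 250 nM
- compound 3 `CCCCc1cc2cc(C(C)N(O)C(=O)CCCC(=O)OC)ccc2o1`, this assay 50 nM

Compound 2 holds the second highest of the three numbers. Its nearest neighbour is compound 1, whose number is higher by a margin that lies within the scatter, so the two cannot be ordered. Compound 3 stands furthest from compound 2, with a lower number by a margin beyond the scatter. Among the compounds with values here, no pair among the three differs in a single place, so no single step is quantified within the measured set.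

Compound 4 `CC(c1ccc2oc(-c3ccccc3)cc2c1)N(O)C(N)=O` differs from compound 2 in one place: amino in place of thiophen-2-yl on a carbonyl carbon. Within the data shown here, no measured pair shows this change, so its size is not known from the data. The expectation is a modest move toward a lower number, of a size that may not clear the scatter. Compound 4 is estimated at 150 nM, with a range from 40 nM to 500 nM. The expected step is a 1.7-fold lower number from compound 2 to compound 4 (0.22 log units; within the scatter).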

Compound 4, half-maximal inhibitory concentration: 410 nM
Compound 4: the middle estimate sits 2.7-fold (0.44 log units) below what was measured, within the range that was stated.
By their numbers in this assay, from the lowest: compound 3; then compounds 2, 1 and 4 (each within the scatter of the next).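

In this assay, within the data shown here, amino in place of thiophen-2-yl on a carbonyl carbon gives a 1.6-fold higher number from compound 2 to compound 4 (0.21 log units; within the scatter), the first single-place step. On this core, the position therefore accepts a single nitrogen in place of a five-membered aromatic ring without a change that can be told from the scatter, so compound 2 and compound 4 cannot be ordered. Nothing measured on these compounds accounts for this result.

Open, as far as these compounds go, is whether a carboxylic acid, a dimethylamino group or a longer alkyl chain on the same carbonyl carbon would also stay within the scatter of compound 2. From the compounds shown here alone, this step rests on a single pair, and whether it holds on the core of compound 1 or of compound 3 remains open.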